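The compounds below may be only part of what the source reports. "The series", "measured", "known", "first", "only" and "open" are said of these compounds alone.

Of the compounds shown here, three on a shared core have been measured: compound 1 is `COc1cc(NC(=O)Nc2cc(Nc3ccc(C)c(F)c3)ncn2)cc(OC)c1`, compound 2 is `COc1cc(NC(=O)Nc2cc(Nc3ccc(OC)c(I)c3)ncn2)cc(OC)c1` and compound 3 is `COc1cc(NC(=O)Nc2cc(Nc3ccc(F)c(Cl)c3)ncn2)cc(OC)c1`. In a functional assay on PC-9 cells (Homo sapiens) for inhibition, read by MTT assay, with a stated time of 48 h, tested at 10 uM (on this read-out higher numbers stand for more inhibition at the one concentration tested (going by the name of the read-out) and lower numbers for less inhibition), compound 1 gives 77.5%, compound 2 gives 47.1% and compound 3 gives 77.5%. Compound 3 therefore stands level with compound 1 at the digits shown, the two together the highest of the three numbers, while compound 2 sits lowest; the steps read no change at the digits printed from compound 1 to compound 3 (within the scatter) and a number 30.4 percentage points higher from compound 2 to compound 3 (beyond the scatter).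

Compound 4 is `COc1cc(NC(=O)Nc2cc(Nc3cc(I)ccc3OC)ncn2)cc(OC)c1` and awaits measurement in this assay. Relative to compound 3 the change is 5-iodo-2-methoxyphenyl in place of 3-chloro-4-fluorophenyl on a nitrogen on an aromatic ring. Among the compounds with values here, two measured steps bear on it, a number 30.4 percentage points lower from compound 1 to compound 2 (beyond the scatter) and a number 30.4 percentage points higher from compound 2 to compound 3 (beyond the scatter), both large, and both set the iodine-and-methoxy aryl of compound 2 well under the two halogenated aryls of compound 1 and compound 3. Within the data shown here, compound 4 again carries iodine and methoxy, arranged as 5-iodo-2-methoxyphenyl rather than 3-iodo-4-methoxyphenyl; no measured compound holds that arrangement, so the size of the effect is open. A decrease in this assay is nevertheless expected, probably not beyond what compound 2 showed. The expected step is a number 25.5 percentage points lower from compound 3 to compound 4 (beyond the scatter). Compound 4 is estimated at 52%, within a range from 28% to 76%.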

Compound 4, a percentage reported as inhibition, at one concentration (the size of the read-out at that concentration, not a potency): 91%
Compound 4: the middle estimate sits 39 percentage points below what was measured, outside the stated range (above it).
By their numbers in this assay, from the lowest: compound 2; then compounds 1 and 3 (each within the scatter of the next); then compound 4.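

In this assay iodine and methoxy together do not hold the number down at this place on a nitrogen on an aromatic ring: moving from the 3-iodo-4-methoxyphenyl arrangement to the 5-iodo-2-methoxyphenyl arrangement of the same two groups gives a large gain (a number 43.9 percentage points higher from compound 2 to compound 4 (beyond the scatter)). The 5-iodo-2-methoxyphenyl group also reads better than either of the two aryl groups that had stood highest (a number 13.5 percentage points higher from compound 3 to compound 4 (beyond the scatter); a number 13.5 percentage points higher from compound 1 to compound 4 (beyond the scatter)), which makes compound 4 the highest of the four numbers, with all its steps beyond the scatter. Nothing in hand explains why the arrangement of iodine and methoxy on the aryl group matters this much.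

The compounds shown do not separate the share of the methoxy group from that of the iodine within 5-iodo-2-methoxyphenyl, and a reading at one concentration gives no potency. On these data alone, how an amine such as dimethylaminomethyl or a carboxylic acid on this aryl group would read in this assay also stays open.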